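This account rests on a few compounds, and the source may have more. Where it says the series, first, only, none or still open, it means among the compounds named here.

Working notes on the series.

Three compounds share one core. Compound 1 `CC[C@@H]1C(=O)N(CC(C)C)c2cnc(Nc3ccc(C(=O)NC4CCN(C)CC4)cc3OC)nc2N1C1CCCC1` carries no result in an assay on HEK293 cells for binding affinity to serine/threonine-protein kinase PLK1 (Homo sapiens), with a stated time of 1 h; on this read-out higher numbers stand for weaker inhibition and lower numbers for stronger inhibition: the entry for compound 1 reads "not determined" (no result reported), so no number is reported for it. Compound 2 `CC[C@@H]1C(=O)N(C)c2cnc(Nc3ccc(C(=O)NC4CCN(C)CC4)cc3OC)nc2N1CC(C)C` is therefore the only compound with a measured value: in this assay compound 2 gives 6.95 nM, and it stands alone on the numbers shown, with nothing to rank it against.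

Compound 3 `CC[C@@H]1C(=O)N(C)c2cnc(Nc3ccc(C(=O)NC4CCN(C)CC4)cc3OC)nc2N1Cc1cccc(Br)c1` is not yet measured. It differs from compound 2 in one place: 3-bromophenyl in place of isopropyl on a saturated chain carbon bound to a nitrogen on an aromatic ring in a ring. The isobutyl group on the ring nitrogen thus becomes a 3-bromobenzyl group.

Within the data shown here, no step between measured compounds is available, so the size of this change can only be guessed. With the starting point of compound 2 at 6.95 nM, the expectation is that compound 3 will be somewhat weaker, a step from compound 2 to compound 3 of a 2.9-fold higher number from compound 2 to compound 3 (0.46 log units; beyond the scatter) being the estimate, though a result within the scatter would not surprise. Among the measured compounds shown here, for compound 3 the estimate in this assay is 20 nM, with a range from 4 nM to 100 nM; the wide range reflects that only one measured value exists.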

Compound 3, inhibition constant: 5.8 nM
Beside the measured number, compound 3's estimate is 3.4-fold (0.54 log units) above it; measured number inside the range.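

In this assay, among these compounds, replacing isobutyl with 3-bromobenzyl gives a 1.2-fold lower number from compound 2 to compound 3 (0.08 log units; within the scatter), the first step that can be read and the first reading of this position. On a saturated chain carbon bound to a nitrogen on an aromatic ring in a ring, 3-bromophenyl with its 7 heavy atoms and one six-membered aromatic ring takes the place of isopropyl with its 3 heavy atoms, and the two compounds cannot be told apart on this read-out, so this position accepts both an open-chain group and an aromatic one without a change beyond the scatter. No measurement at hand accounts for this result.

The compounds shown leave open whether the bromine contributes anything, since a plain benzyl group would be needed to separate the bromine from the phenyl ring. Among the compounds shown here, they also leave open how far the tolerance at this position extends, for instance to a chain ending in an amine or a carboxylic acid, as only two groups there have values.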